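The compounds below may be only part of what the source reports. "The series", "measured", "known", "first", "only" and "open" are said of these compounds alone.

In a functional assay on MDA-MB-231 cells (Homo sapiens) for antiproliferative activity, read by MTT assay, with a stated time of 48 h (a lower number here means a stronger inhibitor of growth, a higher number a weaker inhibitor of growth), two compounds sharing a core have been measured. Compound 1 (`CCOC(=O)N1N=C(c2ccccc2)CC1c1cc(OC)c(OC)c(OC)c1`) gives 5610 nM, and compound 2 (`COC(=O)N1N=C(c2ccc(OC)cc2)CC1c1cc(OC)c(OC)c(OC)c1`) gives 1990 nM. Compound 2 therefore holds the lower of the two numbers, and its gap to compound 1 lies beyond the usual scatter. These two compounds differ in more than one place, so no single change can be read from them. Compound 3 (`CCOC(=O)N1N=C(c2ccc(OC)cc2)CC1c1cc(OC)c(OC)c(OC)c1`) departs from compound 2 in one place, (methyl in place of hydrogen on a saturated chain carbon bound to an oxygen next to a carbonyl group), which turns methoxycarbonyl to ethoxycarbonyl. Among the compounds with values here, no measured pair isolates this change. Compound 1, which also carries ethoxycarbonyl, gives 5610 nM, a weak hint towards a higher number. In this assay, a small rise is expected, with no step beyond the scatter. The expected change is a 1.3-fold higher number from compound 2 to compound 3 (0.12 log units; within the scatter). For compound 3 the estimated value is 2600 nM, within an expected range of 1000 nM to 6500 nM.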

Compound 3, concentration for 50% growth inhibition: 2660 nM
For compound 3 the middle estimate is 1.0-fold (0.01 log units) below the measured one; low and high end bracket the measured number.
By their numbers in this assay, from the lowest: compounds 2 and 3 (each within the scatter of the next); then compound 1.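

Within the data shown here, compound 3 gives the first single-change reading at each of its two places in this assay. Going from methoxycarbonyl to ethoxycarbonyl gives a 1.3-fold higher number from compound 2 to compound 3 (0.13 log units; within the scatter), so the added methyl on the saturated chain carbon bound to an oxygen next to a carbonyl group leaves the number within the usual scatter. Methoxy in place of hydrogen on an aromatic carbon gives a 2.1-fold lower number from compound 1 to compound 3 (0.32 log units; beyond the scatter), a modest step beyond the scatter, and nothing available here accounts for either step.

The compounds shown leave open whether a longer chain, such as propoxycarbonyl, would stay within the scatter of compound 3. They also leave open whether an amine in place of methoxy on that aromatic carbon would give a step of similar size, or whether the methoxy step would hold with methoxycarbonyl.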